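Spiro series: chloro for fluoro on the aryl ring

The source may report more compounds than this note shows. Statements on the series, on what has been measured and on what is new or still open speak of the compounds shown alone.

Measured in a functional assay on the whole organism (strain Wister albino) for inhibition, with Rattus norvegicus as the target, read by paw edema, with a stated time of 1 h, at a dose of 50 mg/kg by the intraperitoneal route; on this read-out higher numbers stand for more inhibition at the one dose given (going by the name of the read-out) and lower numbers for less inhibition:
compound 1, `Cc1ccc([C@@H]2CN(C)[C@]3(C(=O)Nc4ccccc43)[C@]23Cc2ccccc2C3=O)cc1`, compound 1 gives 56.4%
compound 2, `CN1C[C@@H](c2ccc(F)cc2)[C@@]2(Cc3ccccc3C2=O)[C@@]12C(=O)Nc1ccccc12`, compound 2 gives 40.6%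
compound 3, `CN1C(=O)[C@@]2(c3ccccc31)N(C)C[C@@H](c1ccc(F)cc1)[C@@]21Cc2ccccc2C1=O`, compound 3 gives 52.9%

Compound 3 stands second highest of the three numbers; its gap to compound 1 lies within the scatter, while a number 12.3 percentage points higher from compound 2 to compound 3 (beyond the scatter) lies beyond it. Compound 4, `CN1C(=O)[C@@]2(c3ccccc31)N(C)C[C@@H](c1ccc(Cl)cc1)[C@@]21Cc2ccccc2C1=O`, differs from compound 3 by chloro in place of fluoro on an aromatic carbon, at the place described as para to a large group. For the measured compounds named here, the one measured step at that same aromatic carbon is a number 15.8 percentage points lower from compound 1 to compound 2 (beyond the scatter), a modest drop; the step of a number 12.3 percentage points higher from compound 2 to compound 3 (beyond the scatter) touches a different site and does not bear on this change. Nothing measured sets chloro against fluoro directly. A modest shift in this assay is plausible, but its direction is not fixed by the data, so compound 4 is expected near compound 3. For compound 4 the estimate is 56%, with a range from 42% to 68%, an expected a number 3.1 percentage points higher from compound 3 to compound 4 (within the scatter).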

Compound 4, a percentage reported as inhibition, in the whole organism at one dose (the size of the read-out at that dose, not a potency): 47.2%
The estimate for compound 4 lay 8.8 percentage points above the measured number; the measured number falls inside the stated range.
By their numbers in this assay, from the lowest: compounds 2, 4, 3 and 1 (each within the scatter of the next, the first and the last beyond it).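

In this assay, for the compounds shown here, chloro in place of fluoro gives a number 5.7 percentage points lower from compound 3 to compound 4 (within the scatter), the first direct comparison of two halogens at this aromatic carbon, and this read-out does not separate them on the shared core with the methylated amide nitrogen. No available data point to a cause for this step.

Open, from the compounds shown here alone, is how methyl at this carbon would read with that amide nitrogen methylated. Also open, going by these compounds, is whether a methoxy group, a trifluoromethyl group or an amine here would separate from the halogens.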